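This account rests on a few compounds, and the source may have more. Where it says the series, first, only, none or still open, it means among the compounds named here.

Measured in a functional assay on HL-60 cells (Homo sapiens) for antiproliferative activity, read by MTT assay, with a stated time of 72 h; a lower number here means a stronger inhibitor, a higher number a weaker inhibitor:
- compound 1 `COc1cc(C(=O)c2sc3ccccc3c2-c2ccc(C)cc2)cc(OC)c1OC`: 1400 nM
- compound 2 `COc1ccc(OC)c(-c2c(C(=O)c3cc(OC)c(OC)c(OC)c3)sc3ccccc23)c1`: > 10000 nM

Compound 2 gives only a limit, > 10000 nM, and not a number. In compound 3 `COc1cc(C(=O)c2sc3ccccc3c2Nc2ccccc2)cc(OC)c1OC`, anilino takes the place of 2,5-dimethoxyphenyl on an aromatic carbon (anilino in place of 2,5-dimethoxyphenyl on an aromatic carbon). Going by the values given here, the one measured step bearing on this is an at least 7.1-fold higher number from compound 1 to compound 2 (0.85 log units; beyond the scatter), beyond the scatter, where 2,5-dimethoxyphenyl replaced 4-methylphenyl. As far as these compounds go, removing that group should therefore give a lower number in this assay, of modest size, although anilino itself is untested. The expected step is an at least 3.3-fold lower number from compound 2 to compound 3 (0.52 log units; beyond the scatter). For compound 3 the estimate is 3000 nM, with an expected range of 600 nM to 10000 nM.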

Compound 3, half-maximal inhibitory concentration: 5200 nM
Compound 3: middle estimate off by 1.7-fold (0.24 log units), on the low side, and the stated range covers the measured number.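

With anilino in place of 4-methylphenyl, this assay shows a 3.7-fold higher number from compound 1 to compound 3 (0.57 log units; beyond the scatter), so this position accepts a nitrogen-linked phenyl ring with a measured number, though compound 1 keeps the lower one. Compound 2 stands only as a limit, > 10000 nM. Anilino in place of 2,5-dimethoxyphenyl reads as an at least 1.9-fold lower number from compound 2 to compound 3 (0.28 log units; that floor lies within the scatter), so the true size of this step remains unknown.

Open, as far as these compounds go, is whether the nitrogen link or the phenyl ring on it sets the number. A simple amine or a benzylamino group at this position would bear on that.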